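Adding a Chlorine to a Prostaglandin D2 Receptor Antagonist

The source may hold more compounds than are shown below. What is called first, only, known or untested is meant among the compounds shown, and "the series" means these compounds.

Compound 1 `O=C(O)Cc1sc(Cc2ccccc2)nc1-c1ccc(Cl)cc1`: 50% in an in vitro functional assay on HEK285-7 cells for antagonist activity at prostaglandin D2 receptor 2 (Homo sapiens), read by BRET and beta-arrestin recruitment; on this read-out lower numbers stand for smaller maximal responses and higher numbers for larger maximal responses
Compound 2 `O=C(O)Cc1sc(C(c2ccc(F)cc2)c2ccc(F)cc2)nc1-c1ccccc1`: 80% in this assay
Compound 3 `O=C(O)Cc1sc(C(c2ccccc2)c2ccccc2)nc1-c1ccc(C(F)(F)F)cc1`: 80% in this assay

Compound 2 and compound 3 stand level at the digits shown, their gap lying within the scatter, and together they give the highest numbers of the three. Compound 1 lies clearly below both, beyond the scatter.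

The next compound, compound 4 `O=C(O)Cc1sc(C(c2ccc(F)cc2)c2ccc(F)cc2)nc1-c1ccc(Cl)cc1`, differs from compound 2 in one place: chloro in place of hydrogen on an aromatic carbon. Among the compounds with values here, no measured pair shows this change on its own. Compound 1 also carries a chloro group on that ring, but it differs from compound 2 in a second place as well, so its lower value cannot be read as the effect of the chlorine alone.

With nothing in the measured set pointing either way, the expected step from compound 2 to compound 4 in this assay is a number 5 percentage points lower from compound 2 to compound 4 (within the scatter), that is, none beyond the scatter. Compound 4 is therefore estimated at 75%, with a range from 55% to 95%.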

Compound 4, largest response reached (reported as efficacy), in percent of the reference or control that the assay uses: 80%
For compound 4 the middle estimate is 5 percentage points below the measured one; the measured number falls inside the stated range.
By their numbers in this assay, from the lowest: compound 1; then compounds 2, 3 and 4 (each within the scatter of the next).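

Within the data shown here, compound 4 gives the one clean reading of this change in this assay, where swapping phenyl for 4-chlorophenyl, with the rest of the molecule left as it is, produces no change at the digits printed from compound 2 to compound 4 (within the scatter) as the step. On the background of compound 2, then, this position on the ring carries a chloro group without any shift in maximal response beyond the usual scatter. Nothing available explains why the response holds steady.

From the compounds shown here alone, this is a single step on a single background, so it remains open whether chloro would behave the same way on a compound with a different group in place of the two 4-fluorophenyl rings. Going by these compounds, it is also open whether a methoxy group, an amine or a longer chain at this same position would leave the response equally unchanged.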